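Working notes: from compound 2 to compound 4

This account rests on a few compounds, and the source may have more. Where it says the series, first, only, none or still open, it means among the compounds named here.

Measured in a functional assay on K562 cells (Homo sapiens) for cytotoxicity, read by MTT assay; on this read-out higher numbers stand for weaker inhibition and lower numbers for stronger inhibition:
- Compound 1 `COc1ccc(/C=C/C(=O)c2ccc(OC)c3c2OC(C)(C)C=C3)cc1O`: 630 nM
- Compound 2 `CCCCC(=O)Oc1cc(/C=C/C(=O)c2ccc(OC)c3c2OC(C)(C)C=C3)ccc1OC`: 240 nM
- Compound 3 `COc1ccc(/C=C/C(=O)c2ccc(OC)c3c2OC(C)(C)C=C3)cc1OC(=O)c1ccc(Br)cc1`: 1110 nM

Compound 2 holds the lowest number of the three, and its steps to the other two both lie beyond the scatter. The next compound to be measured in this assay is compound 4 `COc1ccc(/C=C/C(=O)Oc2cc(/C=C/C(=O)c3ccc(OC)c4c3OC(C)(C)C=C4)ccc2OC)cc1`. Its difference from compound 2 is 2-(4-methoxyphenyl)ethenyl in place of butyl on a carbonyl carbon, in words 2-(4-methoxyphenyl)ethenyl in place of butyl on a carbonyl carbon.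

Among the compounds with values here, the closest precedent is a 4.6-fold higher number from compound 2 to compound 3 (0.67 log units; beyond the scatter), where 4-bromophenyl replaces butyl at the same kind of carbonyl carbon, so an aromatic ring also enters there. Two further steps give context: a 2.6-fold lower number from compound 1 to compound 2 (0.42 log units; beyond the scatter) and a 1.8-fold higher number from compound 1 to compound 3 (0.25 log units; within the scatter). Within the data shown here, only compound 3 carries an aromatic ring in this role, and no measured compound carries the double bond of the entering group, so the precedent is thin. A modest step to a higher number is therefore expected, with a wide margin.

For compound 4 the estimated value is 600 nM, with an expected range of 200 nM to 1800 nM.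

The estimated change is a 2.5-fold higher number from compound 2 to compound 4 (0.40 log units; beyond the scatter).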

Compound 4, half-maximal inhibitory concentration: 380 nM
Compound 4: the middle estimate sits 1.6-fold (0.20 log units) above what was measured, and the stated range covers the measured number.
By their numbers in this assay, from the lowest: compounds 2, 4, 1 and 3 (each within the scatter of the next, the first and the last beyond it).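

In this assay, the carbonyl carbon tolerates a much larger group carrying an aromatic ring, since replacing butyl with 2-(4-methoxyphenyl)ethenyl stays within the scatter (a 1.6-fold higher number from compound 2 to compound 4 (0.20 log units; within the scatter)), as does the comparison with the free hydrogen on that oxygen (a 1.7-fold lower number from compound 1 to compound 4 (0.22 log units; within the scatter)). The presence of an aromatic ring in the entering group therefore does not fix the number on its own: 2-(4-methoxyphenyl)ethenyl and 4-bromophenyl, each with such a ring, are separated beyond the scatter (a 2.9-fold lower number from compound 3 to compound 4 (0.47 log units; beyond the scatter)), so compound 3 does not represent every ring-bearing group at this place. No supporting data bear on the origin of this separation.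

The compounds shown leave open whether the double bond, the methoxy group or the bromine accounts for that separation, a question that 4-methoxyphenyl or unsubstituted 2-phenylethenyl on the same carbonyl carbon would help to settle. Also open, as far as these compounds go, is how this place responds to a longer chain such as octyl, or to a group ending in an amine or a carboxylic acid.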